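Piperidine Nitrogen Substituent and Microsomal Half-Life

This account rests on a few compounds, and the source may have more. Where it says the series, first, only, none or still open, it means among the compounds named here.

Two compounds of the series have been run in an ADME assay on microsomes (Rattus norvegicus) for metabolic stability; on this read-out higher numbers stand for a longer-lived compound and lower numbers for a shorter-lived compound. Compound 1 `O=C(c1cscn1)N1CCC(C(=O)N2N=CC[C@H]2c2ccccc2)CC1` gives 0.65 h in this assay. Compound 2 `O=C(C1CCN(C(=O)C(F)(F)F)CC1)N1N=CCC1c1ccccc1` gives 0.483 h in this assay, a number that sits within the scatter of compound 1, so the two cannot be told apart on these data. Compound 3 `O=C(C1CCN(c2ccccc2)CC1)N1N=CCC1c1ccccc1` is the next compound and differs from compound 2 as follows: phenyl in place of (trifluoromethyl)carbonyl on an amine nitrogen in a ring. Within the data shown here, no measured pair shows this change, so no step size is known. In this assay the expected change is a modest drop, a 1.4-fold lower number from compound 2 to compound 3 (0.14 log units; within the scatter), which may yet stay within the scatter. Compound 3 is estimated at 0.35 h, with a range from 0.15 h to 0.8 h.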

Compound 3, half-life: 0.25 h
Compound 3: middle estimate off by 1.4-fold (0.15 log units), on the high side; low and high end bracket the measured number.
By their numbers in this assay, from the lowest: compounds 3, 2 and 1 (each within the scatter of the next, the first and the last beyond it).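

Among these compounds, at the amine nitrogen in the six-membered non-aromatic ring, phenyl in place of (trifluoromethyl)carbonyl gives the first readable step at this position in this assay: a 1.9-fold lower number from compound 2 to compound 3 (0.29 log units; within the scatter). Swapping a carbonyl-linked group for a directly attached aromatic ring of carbon only therefore does not separate the two compounds on this read-out. No supporting data bear on this result.

Going by these compounds, whether a simple alkyl chain or a sulfonyl group on this nitrogen would move the half-life beyond the scatter remains open.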